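Fluoro on the benzyl ring in two hybrid series

The source may hold more compounds than are shown below. What is called first, only, known or untested is meant among the compounds shown, and "the series" means these compounds.

Measured compounds:
compound 1, `C=C1C(=O)O[C@H]2[C@H]1CC/C(Cn1cc(Cn3cc(F)c(=O)n(Cc4ccccc4)c3=O)nn1)=C\CC[C@@]1(C)O[C@@H]21`, 8840 nM
compound 2, `C=C1C(=O)O[C@H]2[C@H]1CC/C(Cn1cc(Cn3cc(F)c(=O)n(Cc4ccc(F)cc4)c3=O)nn1)=C\CC[C@@]1(C)O[C@@H]21`, 4860 nM
compound 3, `C=C1C(=O)O[C@H]2[C@H]1CC/C(COC(=O)Cn1cc(F)c(=O)n(Cc3ccccc3F)c1=O)=C\CC[C@@]1(C)O[C@@H]21`, 3830 nM

Of the compounds shown here, three have been tested in a functional assay on Bel7402/5-FU cells (Homo sapiens) for antiproliferative activity, read by MTT assay, with a stated time of 72 h; a higher number here means a weaker inhibitor, a lower number a stronger inhibitor. Compound 1 gives 8840 nM. Compound 2 gives 4860 nM, and the change that separates them is fluoro in place of hydrogen on an aromatic carbon. Its effect is the step of a 1.8-fold lower number from compound 1 to compound 2 (0.26 log units; within the scatter), which does not rise above the usual scatter of the measurement. Compound 3 gives 3830 nM; its number is the lowest of the three, separated from that of compound 1 by more than the scatter but from that of compound 2 by less. Compound 1 and compound 3 carry different linkers between the shared core and the fluorinated pyrimidinedione; the difference between the two cores is not broken down here.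

Compound 4, `C=C1C(=O)O[C@H]2[C@H]1CC/C(COC(=O)Cn1cc(F)c(=O)n(Cc3ccc(F)cc3F)c1=O)=C\CC[C@@]1(C)O[C@@H]21`, is the not yet measured partner of compound 3. It arises by fluoro in place of hydrogen on an aromatic carbon. Among the compounds with values here, this is the same kind of change as the one from compound 1 to compound 2, but not the same: in compound 2 the entering fluoro stands para to a large group, whereas in compound 4 it stands meta to a fluoro group and para to a large group. Within the data shown here, with only one prior example of this kind of change, and that example within the scatter, a step of similar size is expected from compound 3 to compound 4, namely a 1.5-fold lower number from compound 3 to compound 4 (0.17 log units; within the scatter). Compound 4 is therefore estimated at 2600 nM in this assay, with a plausible range from 1200 nM to 6000 nM.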

Compound 4, half-maximal inhibitory concentration: 5010 nM
Compound 4: the middle estimate sits 1.9-fold (0.28 log units) below what was measured, within the range that was stated.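

In this assay, within the data shown here, going from 2-fluorobenzyl to 2,4-difluorobenzyl gives a 1.3-fold higher number from compound 3 to compound 4 (0.12 log units; within the scatter), so on this core, as on the core of compound 1, the added fluoro produces no step that rises above the usual scatter. Set side by side, the two steps point in opposite directions, but they cannot be told apart: the same change on two cores in this assay, a 1.8-fold lower number (0.26 log units; within the scatter) from compound 1 to compound 2 and a 1.3-fold higher number (0.12 log units; within the scatter) from compound 3 to compound 4, 2.4-fold (0.38 log units) apart, within the scatter of two such steps What this shows is that, across these two pairs, the change leaves the antiproliferative read-out within the scatter on both cores; what it does not show is that the fluoro has a real effect on either core, that the effect is the same on both, or that it reverses from one to the other, as each core rests on a single pair and the entering fluoro already stands in a different setting on the two.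

Still open, on these data alone, is whether a larger group at the same place on the benzyl ring, such as chloro, methoxy or trifluoromethyl, would give a step beyond the scatter on either core. As far as these compounds go, it is also open how a 2-fluorobenzyl or 2,4-difluorobenzyl group would behave on the core of compound 1, or how an amide or a longer chain would behave in place of the ester link of compound 3.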